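From compound 3 to compound 4: a bromophenyl swap

The compounds below may be only part of what the source reports. "The series", "measured", "known", "first", "only" and "open" are said of these compounds alone.

compound 1 `COc1cccc(/C=C2\CCC/C(=C\c3cccc(O)c3)C2=O)c1OC`: 6400 nM
compound 2 `COc1ccc(/C=C2\CCC/C(=C\c3cccc(OC)c3OC)C2=O)cc1OC`: 6400 nM
compound 3 `COc1ccc(/C=C2\CCC/C(=C\c3cccc(Cl)c3)C2=O)cc1OC`: 5100 nM

All three values come from a functional assay on SW-620 cells (Homo sapiens) for cytotoxicity, read by MTT assay, with a stated time of 72 h; a higher number here means a weaker inhibitor, a lower number a stronger inhibitor. Compound 3, at 5100 nM, lies within the scatter of both compound 1 and compound 2, so these numbers do not separate the three compounds. Compound 4 `COc1ccc(/C=C2\CCC/C(=C\c3ccc(Br)cc3)C2=O)cc1OC` differs from compound 3 in one place, on a double-bonded chain carbon bound to a double-bonded ring carbon: 4-bromophenyl in place of 3-chlorophenyl on a double-bonded chain carbon bound to a double-bonded ring carbon. For the measured compounds named here, no measured pair isolates a change of this kind. The close values of the three measured compounds give no reason to expect a large shift, and no direction is favoured. The step of a 1.1-fold higher number from compound 3 to compound 4 (0.03 log units; within the scatter) is expected to stay within the scatter. For compound 4 the estimated value is 5500 nM, with an expected range of 2500 nM to 12000 nM.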

Compound 4, half-maximal inhibitory concentration: 5200 nM
Beside the measured number, compound 4's estimate is 1.1-fold (0.02 log units) above it, within the range that was stated.
By their numbers in this assay, from the lowest: compounds 3, 4, 1 and 2 (each within the scatter of the next).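

In this assay, the series now has its first step at a single place, a 1.0-fold higher number from compound 3 to compound 4 (0.01 log units; within the scatter), and it stays within the scatter. On this core, at this place on a double-bonded chain carbon bound to a double-bonded ring carbon, the read-out does not separate 3-chlorophenyl from 4-bromophenyl. No supporting evidence bears on this result.

On these data alone, the swap changes both the halogen and its ring position, so the contribution of each remains open. Also open, as far as these compounds go, is whether a phenyl carrying an amine or a carboxylic acid at this place would move the number beyond the scatter.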